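A few compounds are considered here, and "the series" means these few. Any claim that something is new, unique, unknown or untested is made for them only; others in the source may bear on it.

Two compounds of the series are in hand. Compound 1 `Cc1cc(C)c(NC(=O)N(Cc2cc(-c3ccccc3)cs2)C2CCCCCC2)c(C)c1` was tested in a functional assay on a cell-free system (plasma) with sterol O-acyltransferase, Soat (Rattus norvegicus) as the target; a lower number here means that less compound is needed, a higher number that more compound is needed for the effect. For compound 1 the result in this assay is a limit, < 1 mg/kg, as recorded by the limit of < 1 mg/kg in this assay, at which 1 of the 2 values shown sits. Compound 2 `Cc1cc(C)c(NC(=O)N(Cc2ccc(-c3nnc(C)o3)cc2)C2CCCCCC2)c(C)c1` was run in the same setting. For compound 2 the reading in this assay is also a limit, > 0.32 mg/kg, recorded by the limit of > 0.32 mg/kg in this assay, at which 1 of the 2 values shown sits. Going by the values given here, with both readings limits, no step between compound 1 and compound 2 can be sized, and compound 2 stands only as an open range with nothing fixed around it. Compound 3 `Cc1cc(C)c(NC(=O)N(Cc2ccc(-c3cccnc3)cc2)C2CCCCCC2)c(C)c1` differs from compound 2 in one place: pyridin-3-yl in place of 5-methyl-1,3,4-oxadiazol-2-yl on an aromatic carbon. Without a measured step to lean on, the step from compound 2 to compound 3 is expected to be small, a step that the limit leaves unreadable from compound 2 to compound 3, not clearly beyond the scatter in either direction. Compound 3 is therefore expected to give about 1 mg/kg in this assay, within 0.3 mg/kg to 3 mg/kg.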

Compound 3, dose for half-maximal effect: 0.58 mg/kg
For compound 3 the middle estimate is 1.7-fold (0.24 log units) above the measured one; measured number inside the range.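

No new step can be read from compound 2 to compound 3 in this assay, as the reading of compound 2 is only a limit: the limit of > 0.32 mg/kg in this assay, at which 1 of the 3 values shown sits. What the compounds shown leave open is the size and direction of the change from 5-methyl-1,3,4-oxadiazol-2-yl to pyridin-3-yl.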